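The source may hold more compounds than are shown below. What is called first, only, known or untested is meant among the compounds shown, and "the series" means these compounds.

Compound 1 `O=C(O)c1cc(-c2cccc(COc3ccc4c(c3)CN(c3ccccc3)C4=O)c2)ccc1Cl` gives 260 nM in an assay on HEK293 cells for positive allosteric modulation of metabotropic glutamate receptor 2 (Rattus norvegicus), read by thallium flux; on this read-out higher numbers stand for an effect only at larger amounts of compound and lower numbers for an effect already at smaller amounts; compound 2 `O=C(O)c1cc(-c2cccc(COc3ccc4c(c3)CN(Cc3ccc(C(F)(F)F)cc3)C4=O)c2)ccc1Cl` gives 350 nM. Of these two numbers, compound 1 holds the lower, but the step of a 1.3-fold higher number from compound 1 to compound 2 (0.13 log units; within the scatter) stays within the scatter. Compound 3 `O=C(O)c1cc(-c2cccc(COc3ccc4c(c3)CN(C3CCCCC3)C4=O)c2)ccc1Cl` differs from compound 1 by cyclohexyl in place of phenyl on an amide-type nitrogen in a ring. Within the data shown here, the only measured change at this nitrogen is that from compound 1 to compound 2, which left this assay unmoved beyond the scatter; no measured step puts a non-aromatic ring there. The expected step is therefore a 1.5-fold higher number from compound 1 to compound 3 (0.19 log units; within the scatter), a slight rise at most and with wide uncertainty. Compound 3 is estimated at 400 nM, within 150 nM to 1200 nM.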

Compound 3, half-maximal effective concentration: 270 nM
Beside the measured number, compound 3's estimate is 1.5-fold (0.17 log units) above it, and the stated range covers the measured number.
By their numbers in this assay, from the lowest: compounds 1, 3 and 2 (each within the scatter of the next).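

On the amide-type nitrogen in a ring, cyclohexyl replaces the aromatic phenyl without a change beyond the scatter in this assay (a 1.0-fold higher number from compound 1 to compound 3 (0.02 log units; within the scatter)). The comparison with the 4-(trifluoromethyl)benzyl group reads the same (a 1.3-fold lower number from compound 2 to compound 3 (0.11 log units; within the scatter)), so this read-out does not separate the three groups, aromatic or non-aromatic ring alike. No evidence on the reason for this flat result is available. Open, on these data alone, is whether a smaller methyl or a piperidine ring with its amine on this nitrogen would stay within the same range. Also open, as far as these compounds go, is whether changes elsewhere on the shared core would be equally flat.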